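The source may report more compounds than this note shows. Statements on the series, on what has been measured and on what is new or still open speak of the compounds shown alone.

Working notes on the series, in an assay on cells for inhibition of phosphatidylcholine:ceramide cholinephosphotransferase 2 (Homo sapiens), read by mass spectrometry, with stated times of 60 min and 30 min; a lower number here means a stronger inhibitor, a higher number a weaker inhibitor.

For the measured compounds named here, compound 1 `CCCOc1c(C(=O)N(C)Cc2cc(C(F)(F)F)cc(C(F)(F)F)c2)c(=O)n(C)c2ccccc12` gives 2100 nM in this assay, the highest of the three numbers so far. Compound 2 `CCOc1cc(CN(C)C(=O)c2c(OCCCC3CCN(C(=O)OC(C)(C)C)CC3)c3ccccc3n(C)c2=O)cc(OCC)c1` gives 380 nM, a gap to compound 1 beyond the scatter. Compound 3 `COc1cc(CN(C)C(=O)c2c(OCCCC3CCN(C(=O)OC(C)(C)C)CC3)c3cnccc3n(C)c2=O)cc(OC)c1` gives 1600 nM, a number within the scatter of that of compound 1; no order between these two is read. Going by the values given here, compounds 2 and 3 both carry a longer chain ending in a saturated ring and differ from compound 1 in several places at once, so no single step among measured compounds is available.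

Compound 4 `CN(Cc1cc(C(F)(F)F)cc(C(F)(F)F)c1)C(=O)c1c(OCCCC2CCCCC2)c2ccccc2n(C)c1=O` is not yet measured. It differs from compound 1 by cyclohexyl in place of hydrogen on a saturated chain carbon, three bonds along the chain from an oxygen on an aromatic ring; read one bond further out, propyl becomes 3-cyclohexylpropyl. Compounds 2 and 3, with chains ending in a ring, sit at or below compound 1, so a move toward a lower number is expected for compound 4, of moderate size and with wide uncertainty. The expected step is a 2.6-fold lower number from compound 1 to compound 4 (0.42 log units; beyond the scatter). Compound 4 is estimated at 800 nM, with a range from 250 nM to 2600 nM.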

Compound 4, half-maximal inhibitory concentration: 480 nM
Compound 4: the middle estimate sits 1.7-fold (0.22 log units) above what was measured, and the stated range covers the measured number.
By their numbers in this assay, from the lowest: compounds 2 and 4 (each within the scatter of the next); then compounds 3 and 1 (each within the scatter of the next).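

In this assay, for the compounds shown here, cyclohexyl in place of hydrogen on the saturated chain carbon gives a 4.4-fold lower number from compound 1 to compound 4 (0.64 log units; beyond the scatter) and provides the first comparison that differs in one place. This chain position therefore accepts the added ring, and the step lies beyond the scatter with the rest of compound 1 unchanged. No available data bear on the cause of this step.

The compounds shown leave open whether the ring itself matters or the added chain length alone is enough; an unbranched longer chain such as hexyl, or the shorter cyclohexylmethyl, would separate these two readings. Also open, as far as these compounds go, is how an amine or a carboxylic acid at the end of the chain would compare with cyclohexyl on the same core.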